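The source may report more compounds than this note shows. Statements on the series, on what has been measured and on what is new or still open speak of the compounds shown alone.

Measured so far:
- compound 1 `O=C1C[C@H](O)CC(CCc2cccc3ccccc23)O1` gives 81000 nM in an assay on isolated protein for inhibition of 3-hydroxy-3-methylglutaryl-coenzyme A reductase (Rattus norvegicus); on this read-out lower numbers stand for stronger inhibition and higher numbers for weaker inhibition
- compound 2 `O=C1C[C@H](O)CC(CCc2ccc(Cl)c3cc(Cl)ccc23)O1` gives 7000 nM in this assay
- compound 3 `Cc1ccc2c(C)cc(C)c(CCC3C[C@@H](O)CC(=O)O3)c2c1` gives 360 nM in this assay

All three share the same lactone-bearing core and differ only in the substituents on their fused aromatic ring system. Compound 3 stands lowest of the three numbers, which on this read-out means the strongest inhibition. Its nearest neighbour is compound 2, whose number lies well beyond the scatter above it, and compound 1 lies further still.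

The next compound keeps the core of compound 3 and changes one substituent: compound 4 `Cc1cc(C)c2ccc(Cl)cc2c1CCC1C[C@@H](O)CC(=O)O1` carries chloro in place of methyl on an aromatic carbon. For the measured compounds named here, no measured pair shows this exact exchange, so the expectation rests on compound 3 alone. A single atom swapped for a single atom, with no change in ring count, donors or acceptors, is expected to shift this assay only modestly, in either direction or not beyond the scatter. The expected step is a 1.4-fold higher number from compound 3 to compound 4 (0.14 log units; within the scatter). For compound 4 the estimate is 500 nM, with a range from 150 nM to 1500 nM.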

Compound 4, half-maximal inhibitory concentration: 200 nM
The estimate for compound 4 lay 2.5-fold (0.40 log units) above the measured number; low and high end bracket the measured number.
By their numbers in this assay, from the lowest: compounds 4 and 3 (each within the scatter of the next); then compound 2; then compound 1.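

Chloro in place of methyl on an aromatic carbon gives a 1.8-fold lower number from compound 3 to compound 4 (0.26 log units; within the scatter) in this assay, so this measurement does not tell the two groups apart at this position. The earlier compounds shown here offered no pair differing in one place, and this pair now shows that a methyl group on this carbon, meta to a fused ring and para to a fused ring, can give way to chloro with no shift beyond the usual scatter. No other measurement bears on this result or accounts for it.

From the compounds shown here alone, it remains open how an amine, a methoxy group or a carboxylic acid on this same carbon would read in this assay. Also open, going by these compounds, is whether the same exchange at either remaining methyl group of compound 4 would leave the number similarly close.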